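Swapping the side chain between two weakly cytotoxic sulfonylureas

The compounds below may be only part of what the source reports. "The series", "measured", "known", "first", "only" and "open" are said of these compounds alone.

Measured so far:
Compound 1, `O=C1c2ccccc2NS(=O)(=O)N1Cc1ccccc1`: > 50 ug/mL
Compound 2, `CC(=O)OCCOCN1C(=O)c2ccccc2NS1(=O)=O`: > 200 ug/mL

In a functional assay on HEL cells (Homo sapiens) (a lower number here means that less compound is tolerated, a higher number that more compound is tolerated), compound 1 gives > 50 ug/mL, which is a limit of the assay and not a number. In the same assay compound 2 gives > 200 ug/mL, also a limit. The step that the two limits leave unreadable from compound 1 to compound 2 therefore has no readable size: both values are limits. Compound 2 stands at the limit of > 200 ug/mL in this assay, at which 1 of the 2 values shown sits, while compound 1 stands at the limit of > 50 ug/mL in this assay, at which 1 of the 2 values shown sits.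

Compound 3, `O=C1c2ccccc2NS(=O)(=O)N1COCc1ccccc1`, differs from compound 2 by phenyl in place of acetoxymethyl on a saturated chain carbon bound to an oxygen on a saturated carbon. Within the data shown here, the only measured step, a step that the two limits leave unreadable from compound 1 to compound 2, is unreadable, so no size can be drawn from it. Since neither measured compound showed cytotoxicity within the tested range, compound 3 is expected to behave alike. For compound 3 the estimate is 120 ug/mL, ranging from 40 ug/mL to 250 ug/mL. The expected step of an at least 1.6-fold lower number from compound 2 to compound 3 (0.22 log units; that floor lies within the scatter) is thus within the scatter, most likely again reported as a limit.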

Compound 3, half-maximal cytotoxic concentration: 148 ug/mL
Compound 3: middle estimate off by 1.2-fold (0.09 log units), on the low side, within the range that was stated.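

In this assay compound 3 gives 148 ug/mL as the only real number among the compounds shown, so with phenyl at this place on the side chain a half-maximal cytotoxic concentration can be read. The value for compound 2 is a limit of the assay and not a number: the limit of > 200 ug/mL in this assay, at which 1 of the 3 values shown sits. Replacing acetoxymethyl with phenyl therefore gives an at least 1.3-fold lower number from compound 2 to compound 3 (0.13 log units; that floor lies within the scatter), and this is only a floor, so the real step could be larger, but what is readable so far does not separate the two compounds.

As far as these compounds go, how far the value of compound 3 depends on the phenyl itself remains open, since no other ring stands at this place. Equally open, from the compounds shown here alone, is what an amine, a carboxylic acid or a longer chain at the same carbon would do to the tolerated concentration.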